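The source may hold more compounds than are shown below. What is called first, only, known or untested is meant among the compounds shown, and "the series" means these compounds.

Measured compounds in a functional assay on UO-31 cells (Homo sapiens) for inhibition, read by sulforhodamine B assay, with a stated time of 48 h; on this read-out lower numbers stand for higher toxicity in this test and higher numbers for lower toxicity in this test:
compound 1 `COc1cc(C)cc(-c2c(-c3ccnc(-c4ccc(N(C)C)cc4)c3)cnn2CC#N)c1` gives > 100000 nM, a limit of the assay and not a number.
compound 2 `COc1cc(C)cc(-c2nn(CC#N)cc2-c2ccnc(-c3ccc(N(C)C)cc3)c2)c1` gives > 100000 nM, likewise a limit.
compound 3 `COc1cc(C)cc(-c2nn(CC#N)cc2-c2ccc(-c3cccc(C(C)=O)c3)nc2)c1` gives > 100000 nM, likewise a limit.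

Compound 2 therefore stands nowhere apart from the others: its value is a limit, and all three measured compounds sit at the limit of > 100000 nM in this assay, at which 3 of the 3 values shown sit. Among the compounds with values here, no two measured compounds differ in one place, so no measured step exists. Compound 4 `Cc1cc(O)cc(-c2nn(CC#N)cc2-c2ccnc(-c3ccc(N(C)C)cc3)c2)c1` differs from compound 2 by hydrogen in place of methyl on an oxygen on an aromatic ring. Within the data shown here, with three limits and no measured step, the step that the limit leaves unreadable from compound 2 to compound 4 is expected to be none beyond the scatter, with another limit the likeliest outcome. For compound 4 the estimate in this assay is 150000 nM, within 50000 nM to 500000 nM.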

Compound 4, concentration lethal to 50% of the cells: > 100000 nM
Compound 4 gave a limit, no number; the forecaster's own chance of this, stated with the estimate: 80%; the middle value does not contradict the limit.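

Compound 2 and compound 4 both end at a limit in this assay, not at a number, so the step from methoxy to hydroxy cannot be read. The compounds shown leave open whether any member of this series gives a measurable value in this assay: the limit of > 100000 nM in this assay, at which 4 of the 4 values shown sit.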